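The source may hold more compounds than are shown below. What is called first, only, known or untested is meant among the compounds shown, and "the series" means these compounds.

Of the compounds shown here, three sharing one core have been tested in a functional assay on HEK293 cells for agonist activity at lutropin-choriogonadotropic hormone receptor (Homo sapiens), read by cAMP accumulation; on this read-out lower numbers stand for smaller maximal responses and higher numbers for larger maximal responses. Compound 1 `CSc1nc(-c2cccc(F)c2)c2c(N)c(C(=O)NC(C)(C)C)sc2n1` gives 51.1%, compound 3 `COc1cccc(-c2nc(SC)nc3sc(C(=O)NC(C)(C)C)c(N)c23)c1OC` gives 50.1%, and compound 2 `COc1cccc(-c2nc(SC)nc3sc(C(=O)NCCO)c(N)c23)c1` gives 20.5%, the lowest of the three; its distances to compound 3 and to compound 1 both lie beyond the scatter. Compound 4 `COc1cccc(-c2nc(SC)nc3sc(C(=O)NCc4ccccc4)c(N)c23)c1` has not yet been measured. It differs from compound 2 in one place: phenyl in place of hydroxymethyl on a saturated chain carbon bound to an amide-type nitrogen. For the measured compounds named here, no single-change step between measured compounds is available to set the size of this change. Since compound 1 gives 51.1% and compound 3 gives 50.1%, both standing above the number of compound 2 by distances beyond the scatter, the step of a number 24.5 percentage points higher from compound 2 to compound 4 (beyond the scatter) is expected to be upward and beyond the scatter. Compound 4 is therefore estimated at 45%, within 25% to 65%.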

Compound 4, largest response reached (reported as efficacy), in percent of the reference or control that the assay uses: 7.8%
Compound 4: middle estimate off by 37.2 percentage points, on the high side; the measured number lies below the stated range.
By their numbers in this assay, from the lowest: compound 4; then compound 2; then compounds 3 and 1 (each within the scatter of the next).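

Within this assay the change from 2-hydroxyethyl to benzyl on the amide gives a number 12.7 percentage points lower from compound 2 to compound 4 (beyond the scatter) and so shows that this position responds to the swap, and that here an aromatic ring of carbon only takes the response down rather than up. Nothing available explains this drop. This single pair cannot separate the loss of the hydroxyl from the arrival of the phenyl. Going by these compounds, how an amine, a carboxylic acid or a longer chain at this place would compare also stays open.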